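The compounds below may be only part of what the source reports. "The series", "measured", "known", "first", "only" and "open" are said of these compounds alone.

Working notes on the series. Compound 1 `O=C(O)[C@H]1CC[C@@]2(CC1)OC[C@]1(OO2)C2CC3CC(C2)CC1C3` is the carboxylic acid of the shared core. In a functional assay on SW480 cells (Homo sapiens) for cytotoxicity, read by MTT assay, with a stated time of 48 h (a lower number here means a stronger inhibitor, a higher number a weaker inhibitor), compound 1 gives only a limit, > 100000 nM, so its position on the shown numbers is undefined beyond that limit (the limit of > 100000 nM in this assay, at which 1 of the 2 values shown sits). Among the measured compounds shown here, compound 2 `Oc1ccc(NC2CCC3(CC2)OCC2(CO3)C3CC4CC(C3)CC2C4)c2cccnc12` also gives only a limit in this assay, > 50000 nM, with no further step between the measured compounds. Compound 3 `O=C(NO)[C@H]1CC[C@@]2(CC1)OC[C@]1(OO2)C2CC3CC(C2)CC1C3` differs from compound 1 by hydroxyamino in place of hydroxy on a carbonyl carbon. A modest gain is expected, as an at least 1.6-fold lower number from compound 1 to compound 3 (0.22 log units; that floor lies within the scatter), with a good chance that this assay again reports only a limit. Compound 3 is estimated at 60000 nM, within 5000 nM to 200000 nM.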

Compound 3, half-maximal inhibitory concentration: > 50000 nM
Compound 3 ended at the assay's limit; the forecaster's own chance of this, stated with the estimate: 60%; the middle value lies beyond the limit too.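

The values of compound 1 and compound 3 in this assay are both limits, and the step between them cannot be read. The compounds shown leave open whether hydroxyamino in place of hydroxy on a carbonyl carbon changes the read-out at all.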